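Extending the meta substituent on the pendant aryl ring

The source may hold more compounds than are shown below. What is called first, only, known or untested is meant among the compounds shown, and "the series" means these compounds.

Measured compounds in an assay for inhibition of inositol hexakisphosphate kinase 3 (Homo sapiens), read by colorimetric assay, coupled enzyme assay and malachite green, with a stated time of 120 min, in the presence of a further agent that is not named here; on this read-out lower numbers stand for stronger inhibition and higher numbers for weaker inhibition:
Compound 1 `Cc1cccc(-c2onc3ccc(/C=C/C(=O)O)cc23)c1` gives 3590 nM.
Compound 2 `O=C(O)c1ccc2noc(-c3ccc(NC(=O)c4ccncn4)cc3)c2c1` gives 430 nM.
Compound 3 `Cc1cccc(-c2onc3ccc(C(=O)O)cc23)c1` gives 1410 nM.

Compound 3 stands second highest of the three numbers in this assay. Its nearest neighbour is compound 1, and the shared step runs a 2.5-fold lower number from compound 1 to compound 3 (0.41 log units; beyond the scatter), the change being a carboxy in place of a 2-carboxyethenyl on an aromatic carbon. Among the compounds with values here, compound 2, the furthest of the three, shows a lower number than compound 3, but no single-point step links them.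

Compound 4 `O=C(O)c1ccc2noc(-c3cccc(Oc4ccccn4)c3)c2c1` differs from compound 3 by (pyridin-2-yl)oxy in place of methyl on an aromatic carbon. Within the data shown here, the only measured step, from compound 1 to compound 3, alters the acid side of the core and not the pendant aryl ring, so it does not bear on this change directly. Compound 2 shows that a larger group carried on the pendant ring is compatible with a lower number, yet its position and attachment differ from those in compound 4. The step is therefore expected to be a 1.8-fold lower number from compound 3 to compound 4 (0.25 log units; within the scatter), a modest lowering with wide uncertainty. Compound 4 is estimated at 800 nM, within 250 nM to 2500 nM.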

Compound 4, half-maximal inhibitory concentration: 10900 nM
Beside the measured number, compound 4's estimate is 14-fold (1.13 log units) below it; the measured number lies above the stated range.
By their numbers in this assay, from the lowest: compound 2; then compound 3; then compound 1; then compound 4.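

In this assay, putting (pyridin-2-yl)oxy in place of methyl on this aromatic carbon, meta to a large group, gives a 7.7-fold higher number from compound 3 to compound 4 (0.89 log units; beyond the scatter), a change toward weaker inhibition. Within the data shown here, the earlier step touched only the acid side of the core, so this is the first reading at this position of the pendant aryl ring, and here the larger group with its added six-membered aromatic ring raises the number instead of leaving it unchanged or lowering it. Nothing in the data shown accounts for this rise.

On these data alone, it remains open whether a phenoxy group, with carbon in place of the ring nitrogen, would give the same rise, or whether a smaller methoxy group would stay close to methyl. Also open, as far as these compounds go, is how an amine or an amide at this same position would read.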